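The compounds below may be only part of what the source reports. "The series", "measured", "known", "first", "only" and "open" are said of these compounds alone.

Compound 3 `COc1ccc(C(=O)/C=C/c2cc(-c3cc(OC)c(OC)c(OC)c3)n[nH]2)cc1OC` is a chalcone-type compound in which a trimethoxyphenyl-substituted pyrazole core is joined through the enone to a 3,4-dimethoxyphenyl ketone. Among the measured compounds shown here, in a functional assay on UO-31 cells (Homo sapiens) for inhibition, read by sulforhodamine B assay, with a stated time of 48 h (a higher number here means a weaker inhibitor of growth, a lower number a stronger inhibitor of growth), compound 3 gives 1280 nM, the lowest of the three numbers measured so far; compound 1 `COc1cc(-c2cc(/C=C/C(=O)c3ccc(N)cc3)[nH]n2)cc(OC)c1OC` is nearest, giving 1360 nM, and compound 2 `COc1cc(-c2cc(/C=C/C(=O)c3ccc(Cl)c(Cl)c3)[nH]n2)cc(OC)c1OC` is furthest, giving 5730 nM. The steps on the ketone aryl group are a 1.1-fold lower number from compound 1 to compound 3 (0.03 log units; within the scatter) and a 4.5-fold lower number from compound 2 to compound 3 (0.65 log units; beyond the scatter), so exchanging that aryl group moves this assay by a modest amount at most.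

Compound 4 `COc1ccc(C(=O)/C=C/c2cc(-c3cc(OC)c(OC)c(OC)c3)n[nH]2)cc1` differs from compound 3 by hydrogen in place of methoxy on an aromatic carbon. For the measured compounds named here, no measured step removes a methoxy group from this aryl ring, so the closest guidance is the pair of steps above, which show that changes on this ring stay within a modest range, and the aminophenyl and dimethoxyphenyl ketones sit within the scatter of each other. Compound 4 is therefore expected to change by a 1.5-fold higher number from compound 3 to compound 4 (0.17 log units; within the scatter), a small step, if any, toward a slightly higher number. Compound 4 is estimated at 1900 nM in this assay, with a range of 700 nM to 5000 nM.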

Compound 4, concentration for 50% growth inhibition: 1450 nM
Compound 4: middle estimate off by 1.3-fold (0.12 log units), on the high side; the range from low to high includes it.
By their numbers in this assay, from the lowest: compounds 3, 1 and 4 (each within the scatter of the next); then compound 2.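

In this assay, the hydrogen in place of the methoxy group ortho to a methoxy group gives a 1.1-fold higher number from compound 3 to compound 4 (0.05 log units; within the scatter), so the 3,4-dimethoxyphenyl and 4-methoxyphenyl ketones cannot be told apart, and this assay gives no sign that the methoxy group at this place matters among the compounds shown. Among the compounds shown here, the single remaining group on the ring can also be methoxy or amino without a readable difference, since methoxy in place of amino gives a 1.1-fold higher number from compound 1 to compound 4 (0.03 log units; within the scatter). For the compounds shown here, the 4-methoxyphenyl ketone differs clearly from the 3,4-dichlorophenyl ketone, with a 4.0-fold lower number from compound 2 to compound 4 (0.60 log units; beyond the scatter), which leaves compound 2 as the one compound set apart from the three others, whose numbers all lie within the scatter of one another.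

The compounds shown leave open whether a plain phenyl ketone with no group on the ring, a hydroxyl group, a carboxylic acid or a single chlorine would stay with the three close compounds or move toward compound 2. Nothing presented here gives a measured reason for any of these numbers or for the place of compound 2.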